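Methoxy for Methyl on the Aryl Sulfone of Compound 2

The source may report more compounds than this note shows. Statements on the series, on what has been measured and on what is new or still open speak of the compounds shown alone.

Measured so far in an assay on isolated protein for displacement of a labelled ligand from metabotropic glutamate receptor 5 (Homo sapiens), with a stated time of 60 min, tested at 1 uM; on this read-out higher numbers stand for more inhibition at the one concentration tested (going by the name of the read-out) and lower numbers for less inhibition:
- compound 1 `CC1CCN(c2c(S(=O)(=O)c3ccc(F)cc3)cnc3cc(Cl)ccc23)CC1` gives 91%
- compound 2 `Cc1ccc(S(=O)(=O)c2cnc3cc(Cl)ccc3c2N2CCC(C)CC2)cc1` gives 94%

Compound 2 stands highest of the two numbers, although its nearest neighbour, compound 1, lies within the scatter of it. Compound 3 `COc1ccc(S(=O)(=O)c2cnc3cc(Cl)ccc3c2N2CCC(C)CC2)cc1` differs from compound 2 by methoxy in place of methyl on an aromatic carbon. Going by the values given here, the one measured step on the same aromatic carbon, a number 3 percentage points higher from compound 1 to compound 2 (within the scatter), stayed within the scatter, so a small step is expected for compound 3 in this assay, with no direction beyond the scatter: a number 4 percentage points lower from compound 2 to compound 3 (within the scatter). Compound 3 is estimated at 90%, between 75% and 99%.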

Compound 3, a percentage reported as inhibition, at one concentration (the size of the read-out at that concentration, not a potency): 79%
The estimate for compound 3 lay 11 percentage points above the measured number; the range from low to high includes it.
By their numbers in this assay, from the lowest: compound 3; then compounds 1 and 2 (each within the scatter of the next).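

In this assay, going by these compounds alone, exchanging the group at this aromatic carbon, para to a large group, had given a number 3 percentage points higher from compound 1 to compound 2 (within the scatter), but methoxy gives a number 15 percentage points lower from compound 2 to compound 3 (beyond the scatter) and a number 12 percentage points lower from compound 1 to compound 3 (beyond the scatter) and so is the first change here to go beyond it. The position therefore does respond to the group it carries, and 4-methoxyphenyl stands apart from the other two aryl sulfones. Nothing at hand explains this step.

Still open, going by these compounds, is whether a hydroxyl or an ethyl group at this carbon would follow methoxy or stay with methyl and fluoro.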